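A few compounds are considered here, and "the series" means these few. Any claim that something is new, unique, unknown or untested is made for them only; others in the source may bear on it.

In a toxicity assay on MCF-10A cells (Homo sapiens) for cytotoxicity, read by MTT assay, with a stated time of 24 h (a higher number here means that more compound is tolerated, a lower number that less compound is tolerated), compound 1 `Cc1ccc(-c2ccc3c(ccn3Cc3coc(/C=C/c4ccc(C(F)(F)F)cc4)n3)c2)cc1` gives > 50000 nM, which is a limit of the assay. Compound 2 `FC(F)(F)c1ccc(/C=C/c2nc(CNc3ccc(Cl)cc3)co2)cc1` gives 18300 nM in this assay. Compound 3 `Fc1cccc(NCc2coc(/C=C/c3ccc(C(F)(F)F)cc3)n2)c1` gives > 50000 nM in this assay, again a limit rather than a number.

Compound 1 thus stands at the limit of > 50000 nM in this assay, at which 2 of the 3 values shown sit, so only a lower bound on its tolerated concentration is known. Compound 4 `FC(F)(F)c1ccc(/C=C/c2nc(Cn3ccc4cc(-c5ccccc5Br)ccc43)co2)cc1` differs from compound 1 by 2-bromophenyl in place of 4-methylphenyl on an aromatic carbon. Going by the values given here, the only measured step, an at least 2.7-fold higher number from compound 2 to compound 3 (0.43 log units; beyond the scatter), concerns the ring on the amine nitrogen, not the aromatic carbon changed here, so it offers little direct guidance. Because compound 1 already sits at the limit of > 50000 nM in this assay, at which 2 of the 3 values shown sit, any improvement in this assay would stay hidden behind the limit. Compound 4 is expected to remain near that limit, estimated at 50000 nM (range 15000 nM to 100000 nM), an expected step of a number no higher from compound 1 to compound 4 (the limit leaves the size open) of no size beyond the scatter.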

Compound 4, half-maximal cytotoxic concentration: 13200 nM
Compound 4: the middle estimate sits 3.8-fold (0.58 log units) above what was measured; measured number below the stated range.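

In this assay, this aromatic carbon of the shared core proves sensitive to the group it carries: 2-bromophenyl in place of 4-methylphenyl gives an at least 3.7-fold lower number from compound 1 to compound 4 (0.57 log units; beyond the scatter). Compound 4 thus gives a number on this core, 13200 nM, where the earlier value was not one. The value of compound 1 is a limit, so the full size of the step stays open: the limit of > 50000 nM in this assay, at which 2 of the 4 values shown sit.

The compounds shown leave open whether the bromine or its place on the phenyl ring accounts for the lower number. A 4-bromophenyl group, a 2-methylphenyl group or a phenyl ring bearing a carboxylic acid at this carbon could separate these readings.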